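Amide to Acid on the Carbonyl of Compound 1

The source may hold more compounds than are shown below. What is called first, only, known or untested is meant among the compounds shown, and "the series" means these compounds.

Compound 1 `COc1ncc(-c2ccc3ncc(C(=O)NCc4ccncc4)n3c2)cc1NS(=O)(=O)c1ccc(F)cc1F` is the anchor of this short series. Going by the values given here, in a functional assay on A549 cells (Homo sapiens) for antiproliferative activity, read by sulforhodamine B assay, with a stated time of 72 h (a higher number here means a weaker inhibitor, a lower number a stronger inhibitor), compound 1 gives 500 nM, the only full number among the three measured compounds. Compound 2 `CCOC(=O)c1cc2cc(-c3cnc(OC)c(NS(=O)(=O)c4ccc(F)cc4)c3)ccc2[nH]1` returns only a limit of this assay, > 20000 nM. Compound 3 `CCOC(=O)c1cn2cc(-c3cnc(OC)c(NS(=O)(=O)c4ccc(F)cc4)c3)ccc2n1` likewise returns only a limit, > 20000 nM. Among the compounds with values here, no two measured compounds differ in a single place, so no single step in this assay has been measured; what can be said is the limit of > 20000 nM in this assay, at which 2 of the 3 values shown sit, which leaves compound 1 standing alone with a number while the two esters give none.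

Compound 4 `COc1ncc(-c2ccc3ncc(C(=O)O)n3c2)cc1NS(=O)(=O)c1ccc(F)cc1F` is the next change, made on compound 1 alone: hydroxy in place of ((pyridin-4-yl)methyl)amino on a carbonyl carbon. The carbonyl keeps its place on the aromatic carbon of the shared core; only what sits on it changes. Within the data shown here, with no measured step to lean on, the expectation rests on the fact that the two compounds without the carbamoyl group, compound 2 and compound 3, reached no number at all. The step from compound 1 to compound 4 is expected to run toward weaker inhibition, well beyond the scatter, at a 16-fold higher number from compound 1 to compound 4 (1.20 log units; beyond the scatter). Compound 4 is therefore estimated at 8000 nM, within a range from 2000 nM to 20000 nM, with a real chance that this assay reports only a limit.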

Compound 4, half-maximal inhibitory concentration: 1150 nM
Beside the measured number, compound 4's estimate is 7.0-fold (0.84 log units) above it; measured number below the stated range.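

In this assay, going by these compounds alone, hydroxy in place of ((pyridin-4-yl)methyl)amino on a carbonyl carbon gives a 2.3-fold higher number from compound 1 to compound 4 (0.36 log units; beyond the scatter), the first single-place step and a modest one. The position therefore tolerates the loss of the whole ((pyridin-4-yl)methyl)amino group, including its six-membered aromatic ring, and the carboxy compound still returns a full number, so that group is not required for measurable antiproliferative activity on this core. Compound 2 and compound 3 remain the only entries without a number, each at a limit of the assay: the limit of > 20000 nM in this assay, at which 2 of the 4 values shown sit.

Within the data shown here, the single step removes the methylene, the amide nitrogen and the pyridine ring together, so it leaves open how much each part contributes, a question that a primary amide or a benzylamide on the same carbonyl carbon would address. It also leaves open whether the ester alone goes with the limits, since compound 2 and compound 3 differ from compound 4 in more than one place and an ethyl ester on the core of compound 4 would isolate that change.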